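Methoxy on compound 2: expected cytotoxicity in the series

The source may hold more compounds than are shown below. What is called first, only, known or untested is meant among the compounds shown, and "the series" means these compounds.

In an ADME assay on MT4 cells (Homo sapiens) for cytotoxicity, read by MTT assay, with a stated time of 4 days (on this read-out higher numbers stand for lower toxicity in this test and lower numbers for higher toxicity in this test), compound 1 `COc1ccccc1-c1oc2ccc(N)cc2c(=O)c1O` gives 222000 nM as its value. Compound 2 `COc1c(-c2ccccc2)oc2ccc(N)cc2c1=O` gives 126000 nM on the same read-out. These two values lie within the scatter of each other, so compound 2 stands level with compound 1 on the numbers available.

Compound 3 `COc1ccccc1-c1oc2ccc(N)cc2c(=O)c1OC` has not yet been measured. Its difference from compound 2 is methoxy in place of hydrogen on an aromatic carbon and in words it is methoxy in place of hydrogen on an aromatic carbon, ortho to a large group. Among the compounds with values here, no measured pair isolates this change, so the expectation has little to rest on. Within the data shown here, the only guide is that compound 1 at 222000 nM and compound 2 at 126000 nM sit close together. No step beyond the scatter is therefore expected in this assay and no firm direction is assigned. The estimated change is a 1.2-fold higher number from compound 2 to compound 3 (0.08 log units; within the scatter) and it is expected to stay within the scatter. For compound 3 the estimated value is 150000 nM with an expected range from 70000 nM to 320000 nM on this read-out.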

Compound 3, half-maximal cytotoxic concentration: 229000 nM
Compound 3: the middle estimate sits 1.5-fold (0.18 log units) below what was measured, and the stated range covers the measured number.
By their numbers in this assay, from the lowest: compounds 2, 1 and 3 (each within the scatter of the next).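

In this assay the series now has its first comparisons of compounds that differ in one place. Methoxy in place of hydrogen on an aromatic carbon, ortho to a large group, gives a 1.8-fold higher number from compound 2 to compound 3 (0.26 log units; within the scatter), so this position tolerates the added methoxy without a step that can be told from the scatter. Methyl in place of hydrogen on an oxygen on an aromatic ring, a single change at a second place, gives a 1.0-fold higher number from compound 1 to compound 3 (0.01 log units; within the scatter), and no measurement at hand bears on the reason for either result.

The compounds shown leave open whether a different group on this aromatic carbon, such as an amine, a carboxylic acid or a longer chain, would give a step beyond the scatter, since methoxy and hydrogen are the only two groups compared there. All three compounds are also compared on this single cytotoxicity read-out, so how the two changes behave on any other measure remains an open question for the series.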